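The compounds below may be only part of what the source reports. "The series", "measured", "known", "first", "only" and "open" are said of these compounds alone.

Going by the values given here, in a functional assay on COLO 205 cells (Homo sapiens) for inhibition, read by sulforhodamine B assay (on this read-out lower numbers stand for stronger inhibition of growth and higher numbers for weaker inhibition of growth), three compounds sharing one core have numbers so far. Compound 1 `Oc1ccc(-c2ccc(-c3ccc(-c4nc5c(O)cccc5[nH]4)cc3)cc2)cc1` gives 2600 nM and carries a 4-hydroxyphenyl group. Compound 2 `COc1ccc(-c2ccc(-c3ccc(-c4nc5c(O)cccc5[nH]4)cc3)cc2)cc1` gives 1630 nM and carries a 4-methoxyphenyl group in the same place. Compound 3 `Oc1cccc2[nH]c(-c3ccc(-c4ccc(-c5cccc(Cl)c5)cc4)cc3)nc12` gives 8600 nM with a 3-chlorophenyl group there, the highest number of the three and so the weakest inhibition of growth.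

Compound 4 `COc1ccc(-c2ccc(-c3ccc(-c4nc5c(O)cccc5[nH]4)cc3)cc2)cc1OC` is still unmeasured. The change 3,4-dimethoxyphenyl in place of 3-chlorophenyl on an aromatic carbon puts 3,4-dimethoxyphenyl in place of 3-chlorophenyl on an aromatic carbon. The closest guide is the step of a 5.3-fold higher number from compound 2 to compound 3 (0.72 log units; beyond the scatter) read in reverse, as compound 4 also carries methoxy on that ring. The step of a 3.3-fold higher number from compound 1 to compound 3 (0.52 log units; beyond the scatter) points the same way and is smaller. The step of a 1.6-fold lower number from compound 1 to compound 2 (0.20 log units; within the scatter) separates the two oxygen-bearing compounds by no more than the scatter. Among the compounds with values here, no measured compound carries a second methoxy group, so that part of the change remains untested.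

A move to a lower number in this assay is therefore expected, beyond the scatter and of modest size. The expected step is a 4.3-fold lower number from compound 3 to compound 4 (0.63 log units; beyond the scatter) in this estimate. Compound 4 is estimated at 2000 nM with an expected range of 800 nM to 4800 nM for the measured value.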

Compound 4, concentration for 50% growth inhibition: 1320 nM
The estimate for compound 4 lay 1.5-fold (0.18 log units) above the measured number; the range from low to high includes it.
By their numbers in this assay, from the lowest: compounds 4, 2 and 1 (each within the scatter of the next); then compound 3.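

In this assay, 3,4-dimethoxyphenyl in place of 3-chlorophenyl gives a 6.5-fold lower number from compound 3 to compound 4 (0.81 log units; beyond the scatter) and so confirms, with a second example, that compound 3 stands apart from the compounds carrying oxygen on this ring. A second methoxy group brings no difference that can be told from the scatter, as a 1.2-fold lower number from compound 2 to compound 4 (0.09 log units; within the scatter) shows, and the comparison with the hydroxy compound, a 2.0-fold lower number from compound 1 to compound 4 (0.29 log units; within the scatter), also stays within it, so compounds 1, 2 and 4 form one group at this position, with compound 3 the only one outside it. Nothing available here explains why the 3-chlorophenyl compound gives the higher number.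

The compounds shown leave open whether that higher number belongs to chlorine itself or to its place on the ring, and how a plain phenyl ring or a 4-chlorophenyl group would compare. As far as these compounds go, it is also open how an amine or a carboxylic acid on this ring, or a longer chain on the oxygen in place of methyl, would read in this assay.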